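The source may hold more compounds than are shown below. What is called first, only, known or untested is meant among the compounds shown, and "the series" means these compounds.

Compound 1 `COc1ccc(NC(=O)C2(C(=O)Nc3ccc(Nc4ncc5cc(C(=O)N(C)C)n(C6CCCC6)c5n4)cc3)CC2)cc1` sits second highest of the three numbers measured in a functional assay on T47D cells (Homo sapiens) for inhibition, read by CCK-8 assay, with a stated time of 72 h, tested at 10 uM (on this read-out higher numbers stand for more inhibition of growth at the one concentration tested and lower numbers for less inhibition of growth), where compound 1 gives 96.1%. Going by the values given here, compound 2 `Cc1ccc(NC(=O)C2(C(=O)Nc3ccc(Nc4ncc5cc(C(=O)N(C)C)n(C6CCCC6)c5n4)cc3)CC2)cc1` gives 99.6%, and compound 3 `CN(C)C(=O)c1cc2cnc(Nc3ccc(NC(=O)C4(C(=O)Nc5ccc(F)cc5)CC4)cc3F)nc2n1C1CCCC1` gives 67.9%, the one value clearly lower than compound 1. Compound 4 `CN(C)C(=O)c1cc2cnc(Nc3ccc(NC(=O)C4(C(=O)Nc5ccccc5)CC4)cc3)nc2n1C1CCCC1` differs from compound 1 by hydrogen in place of methoxy on an aromatic carbon. Among the compounds with values here, only one measured step touches the same place: a number 3.5 percentage points higher from compound 1 to compound 2 (within the scatter), a change that stayed within the scatter. Trading methoxy for hydrogen at that aromatic carbon is therefore expected to move this assay little, if at all. Compound 4 is expected to give about 93%, somewhere between 78% and 100%. That estimate means a step of a number 3.1 percentage points lower from compound 1 to compound 4 (within the scatter), expected to lie within the scatter.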

Compound 4, percent growth inhibition at one concentration: 93.9%
Estimate against measurement, compound 4: 0.9 percentage points below; measured number inside the range.
By their numbers in this assay, from the lowest: compound 3; then compounds 4, 1 and 2 (each within the scatter of the next).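

With hydrogen in place of methoxy, this assay gives a number 2.2 percentage points lower from compound 1 to compound 4 (within the scatter), and hydrogen in place of methyl gives a number 5.7 percentage points lower from compound 2 to compound 4 (within the scatter). The earlier compounds shown here only swapped one group for another at this aromatic carbon, whereas these steps show that the number also holds with no group there at all. Nothing available explains this result.

Still open, as far as these compounds go, is whether a larger or charged group at this carbon, such as an amine or a carboxylic acid, would also leave the number unchanged. A single tested concentration also leaves open whether these three compounds would separate at lower doses.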